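The source may hold more compounds than are shown below. What is called first, only, known or untested is meant among the compounds shown, and "the series" means these compounds.

Compound 3, `c1cc(-c2cn[nH]c2)c2c(c1)C(c1ncc[nH]1)CC2`, is one of three compounds already tested in a functional assay on CHO cells for agonist activity at Alpha-1B adrenergic receptor (Homo sapiens), read by FLIPR and calcium flux; on this read-out higher numbers stand for an effect only at larger amounts of compound and lower numbers for an effect already at smaller amounts. In this assay compound 3 gives only a limit, > 10000 nM. Compound 1, `Clc1ccc2c(c1-c1ccn[nH]1)CCC2c1ncc[nH]1`, which carries both a chloro group and a pyrazolyl group, also gives only a limit in this assay, > 10000 nM. Compound 2, `COc1c(Cl)ccc2c1CCC2c1ncc[nH]1`, gives only a limit as well, > 10000 nM. For the measured compounds named here, the single measured step, a step that the two limits leave unreadable from compound 1 to compound 2, methoxy in place of 1H-pyrazol-5-yl on an aromatic carbon, therefore cannot be read in size or direction. Going by the values given here, every value so far rests on the same ceiling: the limit of > 10000 nM in this assay, at which 3 of the 3 values shown sit.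

Compound 4, `Clc1ccc2c(c1-c1cn[nH]c1)CCC2c1ncc[nH]1`, differs from compound 3 by chloro in place of hydrogen on an aromatic carbon. Among the compounds with values here, no measured step bears on this particular change, and the one step recorded is itself unreadable. The step from compound 3 to compound 4 is consequently expected to be a step that the limit leaves unreadable from compound 3 to compound 4, with no readable direction. Compound 4 is expected to give about 15000 nM in this assay, within a range from 3000 nM to 60000 nM, and most probably again only as a limit.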

Compound 4, half-maximal effective concentration: > 10000 nM
Compound 4 ended at the assay's limit; the forecaster's own chance of this, stated with the estimate: 85%; the middle value is on the limit's open side.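

For the compounds shown here, compound 4, like compound 1, compound 2 and compound 3, gives only a limit in this assay, so no step to compound 4 can be read in size or direction: the limit of > 10000 nM in this assay, at which 4 of the 4 values shown sit. The compounds shown leave open whether any change on the shared core gives a measurable effect in this assay.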